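This account rests on a few compounds, and the source may have more. Where it says the series, first, only, none or still open, it means among the compounds named here.

Values so far from an ADME assay on L929 cells (Mus musculus) for cytotoxicity, read by resazurin assay, with a stated time of 48 h (on this read-out lower numbers stand for higher toxicity in this test and higher numbers for lower toxicity in this test), follow
Compound 1 (`C#CCn1c2ccc([N+](=O)[O-])cc2c(=O)n1Cc1ccccc1`): 195000 nM
Compound 2 (`O=c1c2cc([N+](=O)[O-])ccc2n(CCCBr)n1Cc1ccccc1`): 25200 nM

Compound 2 holds the lower number of the two (25200 nM). The next change leads to compound 3 (`O=C(O)CCn1c2ccc([N+](=O)[O-])cc2c(=O)n1Cc1ccccc1`), with carboxy in place of bromomethyl on a saturated chain carbon, two bonds along the chain from an aromatic nitrogen. Going by the values given here, only one measured step bears on this change (a 7.7-fold lower number from compound 1 to compound 2 (0.89 log units; beyond the scatter)), and it brought in 2-bromoethyl in place of ethynyl. Compound 3 loses the bromomethyl and, like compound 1, carries no bromine. That single step is thin support, since a different group enters here. Even so, a step of similar or slightly smaller size towards a higher number is expected in this assay (a 4.8-fold higher number from compound 2 to compound 3 (0.68 log units; beyond the scatter)). Compound 3 is estimated at 120000 nM (expected range 40000 nM to 400000 nM).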

Compound 3, concentration lethal to 50% of the cells: > 256000 nM
Compound 3 gave a limit, no number (the forecaster's own chance of this, stated with the estimate: 20%); at least 2.1-fold (0.32 log units) between middle value and limit.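

At this position on the chain, carboxy in place of bromomethyl gives an at least 10-fold higher number from compound 2 to compound 3 (1.00 log units; beyond the scatter) in this assay, so compound 2 remains the only one of the three whose number stands clearly low. Against the ethynyl chain the reading is an at least 1.3-fold higher number from compound 1 to compound 3 (0.11 log units; that floor lies within the scatter), so this pair cannot be ordered, and the carboxy end shows no sign of the lower number seen with bromine. Compound 3 gives a limit and not a number: the limit of > 256000 nM in this assay, at which 1 of the 3 values shown sits.

From the compounds shown here alone, how far the true value of compound 3 lies from that limit remains open. A chain ending in chlorine, a hydroxyl or an amine at the same length would show whether the lower number of compound 2 follows the bromine itself or any group other than carboxy.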